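This account rests on a few compounds, and the source may have more. Where it says the series, first, only, none or still open, it means among the compounds named here.

Compound 1 `c1ccc(CN(CCCCN(C[C@H]2Cc3ccccc3CN2)[C@H]2CCCc3cccnc32)Cc2ccccn2)nc1` in a functional assay on cells for agonist activity at C-X-C chemokine receptor type 4 (Homo sapiens), read by fluorescence and calcium flux, with a stated time of 90 s (on this read-out lower numbers stand for an effect already at smaller amounts and higher numbers for an effect only at larger amounts of compound), gives > 30000 nM, which is a limit of the assay.
Compound 2 `c1ccc2c(c1)CN[C@@H](CN(CCCCNCC1CCNCC1)[C@H]1CCCc3cccnc31)C2` in this assay gives > 30000 nM, again a limit of the assay rather than a number.

Going by the values given here, compound 2 therefore stands at the limit of > 30000 nM in this assay, at which 2 of the 2 values shown sit; neither of the two measured compounds has produced a number on this read-out, so there is no measured step to lean on, and nothing more can be said of the pair than that both values show the same limit.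

Compound 3 `CC(C)(CCN(C[C@H]1Cc2ccccc2CN1)[C@H]1CCCc2cccnc21)CNC1CCOCC1` is not yet measured. It differs from compound 2 by a group of 11 heavy atoms (9 carbon, 1 nitrogen, 1 oxygen; one six-membered non-aromatic ring with 1 hetero atom) in place of a group of 10 heavy atoms (8 carbon, 2 nitrogen; one six-membered non-aromatic ring with 1 hetero atom), on a saturated chain carbon, two bonds along the chain from an amine nitrogen.

Among the compounds with values here, with no measured step and with compound 2 at a limit, no direction can be read from the data. The step of a number no higher from compound 2 to compound 3 (the limit leaves the size open) is expected to be none beyond the scatter, because compound 2 sits at the limit of > 30000 nM in this assay, at which 2 of the 2 values shown sit, and nothing shown points away from it. For compound 3 the expected result is 30000 nM, estimated to lie between 5000 nM and 100000 nM, most likely reported again as a limit.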

Compound 3, half-maximal effective concentration: > 30000 nM
Compound 3 was reported as a limit (the forecaster's own chance of this, stated with the estimate: 80%); the middle value sits exactly at the limit.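

Compound 2 and compound 3 both gave a limit of the assay rather than a number, so the step between them cannot be read. All the values shown share one result: the limit of > 30000 nM in this assay, at which 3 of the 3 values shown sit. As far as these compounds go, it remains open whether any compound of this kind gives a number rather than a limit in this assay and how the two groups truly compare.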